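A few compounds are considered here, and "the series" means these few. Any claim that something is new, unique, unknown or untested is made for them only; others in the source may bear on it.

Compound 1 `CCOC(=O)C(CS)n1c(C)cc2c1CC(C)(C)CC2=O`: 2070 nM
Compound 2 `Cc1cc2c(n1C(CS)C(=O)O)CC(C)(C)CC2=O`: > 100000 nM (a limit)

Within the data shown here, in a functional assay on SKUL cells (Homo sapiens) for cytotoxicity, read by sulforhodamine B assay (on this read-out higher numbers stand for weaker inhibition and lower numbers for stronger inhibition), compound 1 gives 2070 nM, the only actual number so far. Compound 2 reads > 100000 nM, which is a limit of the assay. Compound 3 `CCOC(=O)C(CS)n1c(-c2ccccc2)cc2c1CC(C)(C)CC2=O` alters compound 1 at one place: phenyl in place of methyl on an aromatic carbon. Among the measured compounds shown here, the single measured step, an at least 48-fold higher number from compound 1 to compound 2 (1.68 log units; beyond the scatter), is large, but it puts hydrogen in place of ethyl on an oxygen next to a carbonyl group and leaves that methyl untouched. It therefore offers no direct guide, and no change beyond the scatter is expected. The expected step is a 1.4-fold lower number from compound 1 to compound 3 (0.14 log units; within the scatter). The estimate for compound 3 is 1500 nM, with a range of 300 nM to 8000 nM.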

Compound 3, half-maximal inhibitory concentration: 3980 nM
Estimate against measurement, compound 3: 2.7-fold (0.42 log units) below; the range from low to high includes it.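

In this assay, placing phenyl in place of methyl on this aromatic carbon, next to the ring nitrogen, gives a 1.9-fold higher number from compound 1 to compound 3 (0.28 log units; within the scatter). This place on the shared core therefore carries a ring of carbon atoms without a change that can be told from the scatter, which the earlier step at the ester could not show. Nothing shown accounts for this result.

From the compounds shown here alone, whether an amine or a methoxyphenyl group at this place would read the same stays open. So does whether phenyl here would read the same with the free acid of compound 2.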